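Acylation of the aminothiazole nitrogen in a sulfonamide series

The source may hold more compounds than are shown below. What is called first, only, known or untested is meant among the compounds shown, and "the series" means these compounds.

Of the compounds shown here, two have been tested in a functional assay on U-87MG ATCC cells (Homo sapiens) for antiproliferative activity, read by MTT assay, with a stated time of 72 h; a higher number here means a weaker inhibitor, a lower number a stronger inhibitor. Compound 1 `COc1c(NS(=O)(=O)c2ccc(F)cc2)cc(-c2ccc3nc(NC4CC4)sc3n2)cc1C(N)=O` gives 41700 nM. Compound 2 `COc1c(NS(=O)(=O)c2ccc(F)cc2)cc(-c2ccc3nc(NC(C)=O)sc3c2)cc1C(N)=O` carries an acetylamino group and differs in its core as well from compound 1; in this assay compound 2 gives 4750 nM. Within the data shown here, of the two numbers, compound 1 holds the higher one, and the gap between compound 1 and compound 2 lies beyond the scatter of repeated measurements, so compound 1 is the weaker inhibitor of the pair; no single-point step connects the two.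

Compound 3 `COc1c(NS(=O)(=O)c2ccc(F)cc2)cc(-c2ccc3nc(NC(=O)C4CC4)sc3n2)cc1C(N)=O` keeps the core of compound 1 and changes only the substituent on the ring nitrogen: cyclopropylcarbonyl in place of cyclopropyl on a nitrogen on an aromatic ring. Among the measured compounds shown here, both measured compounds bear a nitrogen substituent on the same type of ring, and the one with an acyl group, compound 2, gives the lower number 4750 nM, while the alkyl-substituted compound 1 gives 41700 nM. On that basis the step of a 3.5-fold lower number from compound 1 to compound 3 (0.54 log units; beyond the scatter) is expected to run toward a lower number, beyond the scatter but not as far as the whole gap between the two measured compounds, since their cores differ. Compound 3 is therefore estimated at 12000 nM, within a range of 3500 nM to 40000 nM.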

Compound 3, half-maximal inhibitory concentration: 20500 nM
Estimate against measurement, compound 3: 1.7-fold (0.23 log units) below; low and high end bracket the measured number.
By their numbers in this assay, from the lowest: compound 2; then compound 3; then compound 1.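

In this assay, among these compounds, cyclopropylcarbonyl in place of cyclopropyl on a nitrogen on an aromatic ring gives a 2.0-fold lower number from compound 1 to compound 3 (0.31 log units; beyond the scatter), which is the first reading at this nitrogen with the core held constant. The step is modest but lies beyond the scatter, so on the core of compound 1 the acylated nitrogen is tolerated and the number moves downward, with compound 3 at 20500 nM still in the same general range as its parent. The cyclopropyl ring is present on both sides of the step, and the change by count is the added carbonyl with its one hydrogen-bond acceptor, although no measurement on hand gives a reason for the shift.

Among the compounds shown here, with only this pair, it remains open whether the step belongs to the carbonyl itself or to the particular acyl group, and a plain acetyl, a longer acyl chain such as butanoyl, or a urea on the same nitrogen and core would separate these readings. The free amine on this core would provide the missing reference point for both the alkyl and the acyl substituents.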